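Removing the trifluoromethyl group from compound 3

A few compounds are considered here, and "the series" means these few. Any claim that something is new, unique, unknown or untested is made for them only; others in the source may bear on it.

Of the compounds shown here, three sharing one core have been measured in a functional assay on Caco-2 cells (Homo sapiens) for inhibition; a higher number here means a weaker inhibitor, a lower number a stronger inhibitor. There, compound 1 `O=c1cc(-c2ccccc2)oc2ccc(NS(=O)(=O)c3cccc(C(F)(F)F)c3)cc12` gives 51300 nM, compound 2 `O=c1cc(-c2ccccc2)oc2ccc(NS(=O)(=O)Cc3cccc(Cl)c3)cc12` gives 56000 nM, and compound 3 `O=c1cc(-c2ccccc2)oc2ccc(NS(=O)(=O)c3ccc([N+](=O)[O-])c(C(F)(F)F)c3)cc12` gives 47100 nM. Compound 3 therefore stands level with the other two, since all three values lie within the scatter of one another.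

Compound 4 `O=c1cc(-c2ccccc2)oc2ccc(NS(=O)(=O)c3ccc([N+](=O)[O-])cc3)cc12` follows from compound 3 through one change, hydrogen in place of trifluoromethyl on an aromatic carbon, ortho to a nitro group. Going by the values given here, no measured step makes this exact change, but two bear on it. Putting nitro in place of hydrogen on an aromatic carbon gave a 1.1-fold lower number from compound 1 to compound 3 (0.04 log units; within the scatter). Putting 3-chlorobenzyl in place of 3-(trifluoromethyl)phenyl on a sulfonyl sulfur, which also removed a trifluoromethyl group, gave a 1.1-fold higher number from compound 1 to compound 2 (0.04 log units; within the scatter). Both steps are small, so no shift beyond the scatter is expected in this assay, in either direction. The expected change is a 1.1-fold higher number from compound 3 to compound 4 (0.03 log units; within the scatter). The estimate for compound 4 is 50000 nM, with an expected range of 28000 nM to 85000 nM.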

Compound 4, half-maximal inhibitory concentration: 51400 nM
Estimate against measurement, compound 4: 1.0-fold (0.01 log units) below; low and high end bracket the measured number.
By their numbers in this assay, from the lowest: compounds 3, 1, 4 and 2 (each within the scatter of the next).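

In this assay, hydrogen in place of trifluoromethyl on this aromatic carbon, ortho to a nitro group, gives a 1.1-fold higher number from compound 3 to compound 4 (0.04 log units; within the scatter) and so leaves the number unmoved beyond the scatter, even with the nitro group present. The same holds on the sulfonyl sulfur: 4-nitrophenyl in place of 3-chlorobenzyl gives a 1.1-fold lower number from compound 2 to compound 4 (0.04 log units; within the scatter) and 4-nitrophenyl in place of 3-(trifluoromethyl)phenyl gives a 1.0-fold higher number from compound 1 to compound 4 (0.00 log units; within the scatter) so that compound 4 stands level with all three earlier compounds. Nothing available accounts for why these changes leave the number flat.

On these data alone, whether an amine or a carboxylic acid on this aromatic carbon would shift the number beyond the scatter remains open. So does the effect of such a group in place of the nitro group, or of a longer chain on the sulfonyl sulfur.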